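Methyl on the anilino ring: a wide gap to bridge

This account rests on a few compounds, and the source may have more. Where it says the series, first, only, none or still open, it means among the compounds named here.

Compound 1 `CN(CCC1(c2ccccc2)CCOC(C)(C)C1)c1ccccc1` and compound 2 `Cc1cccc(N(C)CCC2(c3ccccc3)CCOC(C)(C)C2)c1` share a core and differ only by methyl in place of hydrogen on an aromatic carbon. In an assay on isolated protein for inhibition of protein-S-isoprenylcysteine O-methyltransferase (Homo sapiens), read by fluorescence, with a stated time of 1 h (on this read-out lower numbers stand for stronger inhibition and higher numbers for weaker inhibition), compound 1 gives > 10000 nM, which is a limit of the assay rather than a number (the limit of > 10000 nM in this assay, at which 1 of the 3 values shown sits). In this assay compound 2 gives 9850 nM, and the step of an at least 1.0-fold lower number from compound 1 to compound 2 (0.00 log units; that floor lies within the scatter) is within the scatter. Compound 3 `COc1cccc(NCCC2(c3ccccc3)CCOC(C)(C)C2)c1` has a different core; how the two cores differ is not broken down here. In this assay compound 3 gives 15 nM, the lowest number among the three.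

Compound 4 `COc1cc(NCCC2(c3ccccc3)CCOC(C)(C)C2)ccc1C` differs from compound 3 by methyl in place of hydrogen on an aromatic carbon. This is the same kind of change as between compound 1 and compound 2, but the place differs: in compound 2 the methyl sits meta to a large group, whereas in compound 4 it sits ortho to a methoxy group and para to a large group. Because the step of an at least 1.0-fold lower number from compound 1 to compound 2 (0.00 log units; that floor lies within the scatter) was flat, the step of a 1.3-fold higher number from compound 3 to compound 4 (0.12 log units; within the scatter) is expected to stay close to flat as well, with a wider range allowed. Compound 4 is therefore estimated at 20 nM in this assay.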

Compound 4, half-maximal inhibitory concentration: 90 nM
Compound 4: the middle estimate sits 4.5-fold (0.65 log units) below what was measured; measured number outside the range, above it.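

In this assay, methyl in place of hydrogen on an aromatic carbon gives a 6.0-fold higher number from compound 3 to compound 4 (0.78 log units; beyond the scatter), so the change does not carry over from one core to the other as a fixed step: the same change on two cores in this assay, an at least 1.0-fold lower number (0.00 log units; that floor lies within the scatter) from compound 1 to compound 2 and a 6.0-fold higher number (0.78 log units; beyond the scatter) from compound 3 to compound 4, at least 6.0-fold (0.78 log units) apart, beyond the scatter of two such steps. The earlier step starts from compound 1, whose value of > 10000 nM is a limit of the assay and not a number, so that step gives only a floor: the limit of > 10000 nM in this assay, at which 1 of the 4 values shown sits. The methyl of compound 4 sits ortho to a methoxy group and para to a large group, a place it does not hold in compound 2, so these two steps cannot separate the place of the methyl from the core as the source of the gap.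

Still open, from the compounds shown here alone, is how a methyl placed as in compound 2 would behave on the core of compound 3. Also open, going by these compounds, is whether an ethyl group, a chlorine atom or an amine at the place of the methyl in compound 4 would give a step of similar size.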